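Swapping an Imidazole for an Imidazoline on a Fused Core

A few compounds are considered here, and "the series" means these few. Any claim that something is new, unique, unknown or untested is made for them only; others in the source may bear on it.

Compound 1 `CCS(=O)(=O)Nc1cccc2c1SCCC2c1c[nH]cn1` — < 10000 nM
Compound 2 `Cn1cnc(C2CCCc3c(NS(C)(=O)=O)cccc32)c1` — 1050 nM

Of the compounds shown here, two have been tested in an assay on isolated protein for binding affinity to Alpha-1D adrenergic receptor (Rattus norvegicus), read by radioligand binding; on this read-out lower numbers stand for stronger inhibition and higher numbers for weaker inhibition. For compound 1 the result is only a limit of the assay, < 10000 nM, so no number is attached to it. Among the compounds with values here, compound 2 gives 1050 nM in this assay, and it is the only actual number in the set; the other result sits at the limit of < 10000 nM in this assay, at which 1 of the 2 values shown sits. Compound 2 therefore stands alone as the reference point.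

Compound 3 `CS(=O)(=O)Nc1cccc2c1CCCC2C1=NCCN1` has not been measured. It differs from compound 2 in one place: a group of 5 heavy atoms (3 carbon, 2 nitrogen; one five-membered non-aromatic ring with 2 hetero atoms) in place of a group of 6 heavy atoms (4 carbon, 2 nitrogen; one five-membered aromatic ring with 2 hetero atoms), on a saturated ring carbon. Within the data shown here, because no pair of measured compounds differs in a single place, no measured step exists to calibrate this change, and the expectation rests on compound 2 alone. The shift from an aromatic five-membered ring to a non-aromatic one carrying a hydrogen-bond donor is expected to move binding toward stronger affinity, beyond the usual scatter. Compound 3 is expected to give about 200 nM, with a range from 30 nM to 1500 nM. This corresponds to an expected step of a 5.3-fold lower number from compound 2 to compound 3 (0.72 log units; beyond the scatter).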

Compound 3, inhibition constant: 4270 nM
Estimate against measurement, compound 3: 21-fold (1.33 log units) below; measured number outside the range, above it.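

In this assay, putting the five-membered non-aromatic ring in place of 1-methyl-1H-imidazol-4-yl on the saturated ring carbon gives a 4.1-fold higher number from compound 2 to compound 3 (0.61 log units; beyond the scatter) and so weakens binding. Within the data shown here, this is the only measured change in one place here, and it shows that the group on this carbon affects the result: exchanging one five-membered ring with 2 hetero atoms for another moves the number beyond the usual scatter, even though the new ring adds a hydrogen-bond donor. Nothing measured here accounts for the direction or size of this step.

The change alters several things at once, including the methyl group, the aromatic ring and the hydrogen-bond donor, so the compounds shown leave open which of these matters. A plain imidazole without the methyl group on the same core would help to separate them, and an amine or a longer chain on the same saturated ring carbon would show how much else this position can accept.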